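The source may report more compounds than this note shows. Statements on the series, on what has been measured and on what is new or still open speak of the compounds shown alone.

Measured compounds:

In a toxicity assay on HeLa cells (Homo sapiens) for cytotoxicity, read by MTT assay, with a stated time of 24 h (a higher number here means a weaker inhibitor, a lower number a stronger inhibitor), compound 1 `CCOC(=O)N1CCN(C(=S)SCC(O)Cn2c([N+](=O)[O-])cnc2C)CC1` gives 1610000 nM.
In this assay compound 2 `CCCCN1CCN(C(=S)SCC(O)Cn2c([N+](=O)[O-])cnc2C)CC1` gives 1910000 nM.
In this assay compound 3 `CCCCN1CCN(C(=S)SCC(O)Cn2cc([N+](=O)[O-])nc2C)CC1` gives 4330000 nM.

Compounds 1 and 2 share one core and differ in a single place: ethoxycarbonyl in place of butyl on an amine nitrogen in a ring. That change made a 1.2-fold lower number from compound 2 to compound 1 (0.07 log units; within the scatter), so the two numbers cannot be told apart by this measurement.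

Compound 3 carries a different core from compound 2; the difference between the two cores is not broken down here. Compound 3 has the highest number of the three, and its number stands beyond the scatter from both compound 2 and compound 1, so compound 3 is the weakest inhibitor among the measured compounds.

Compound 4 `CCOC(=O)N1CCN(C(=S)SCC(O)Cn2cc([N+](=O)[O-])nc2C)CC1` has not been measured. It is built from compound 3 by the same change that turns compound 2 into compound 1: ethoxycarbonyl in place of butyl on an amine nitrogen in a ring. The place of the change is described in the same words for both pairs, so it is the same change on a different core.

The expectation for compound 4 rests on the step seen once before: because a 1.2-fold lower number from compound 2 to compound 1 (0.07 log units; within the scatter) was within the scatter, the step from compound 3 to compound 4 is expected to be small as well, estimated as a 1.2-fold lower number from compound 3 to compound 4 (0.08 log units; within the scatter). Compound 4 is therefore estimated at 3600000 nM in this assay, with a likely range from 1800000 nM to 7500000 nM.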

Compound 4, half-maximal inhibitory concentration: 2360000 nM
Estimate against measurement, compound 4: 1.5-fold (0.18 log units) above, within the range that was stated.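

On the second core, putting ethoxycarbonyl in place of butyl gives a 1.8-fold lower number from compound 3 to compound 4 (0.26 log units; within the scatter), and the two ethoxycarbonyl compounds, which differ only in having 2-methyl-4-nitro-1H-imidazol-1-yl in place of 2-methyl-5-nitro-1H-imidazol-1-yl, show a 1.5-fold higher number from compound 1 to compound 4 (0.17 log units; within the scatter). In this assay, the change can be carried from one core to the other without a detectable difference in its step, and the two steps can be compared directly: the same change on two cores in this assay, a 1.2-fold lower number (0.07 log units; within the scatter) from compound 2 to compound 1 and a 1.8-fold lower number (0.26 log units; within the scatter) from compound 3 to compound 4, 1.5-fold (0.19 log units) apart, within the scatter of two such steps. This shows agreement only within the limits of the measurement: neither step can be told apart from the scatter, so the data do not show that the change has a real effect on either core, and two pairs cannot show that it would behave the same way on any other core.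

The compounds shown leave open what other groups on the same ring nitrogen would do on these two cores, such as an acetyl group, a benzyl group or a longer chain like octyl. They also leave open whether a carboxylic acid in place of the ethyl ester of the ethoxycarbonyl group would give a step that stands clear of the scatter.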